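Methoxy added to the aryl sulfone of compound 2

This account rests on a few compounds, and the source may have more. Where it says the series, first, only, none or still open, it means among the compounds named here.

Measured compounds:
compound 1, `COc1ccc(S(=O)(=O)c2ccccc2)c(Cc2c3c(n(CC(=O)O)c2C)CCNC3=O)c1`, 3.6 nM
compound 2, `Cc1c(Cc2ccccc2S(=O)(=O)c2ccc(F)cc2)c2c(n1CC(=O)O)CCNC2=O`, 3.3 nM

Both compounds were characterised in a functional assay on CHO.K1 cells for antagonist activity at prostaglandin D2 receptor 2 (Homo sapiens), read by GTPgammaS binding, with a stated time of 1 h; on this read-out higher numbers stand for weaker inhibition and lower numbers for stronger inhibition. Compound 1 gives 3.6 nM there, and compound 2 gives 3.3 nM. Compound 2 thus has the lowest of the two numbers, but compound 1 lies within the scatter of it, so the two cannot be told apart on these data. Compound 1 and compound 2 differ in two places at once, so their values show only that both stand at a similar level.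

Compound 3, `COc1ccc(S(=O)(=O)c2ccc(F)cc2)c(Cc2c3c(n(CC(=O)O)c2C)CCNC3=O)c1`, has not yet been measured in this assay. It differs from compound 2 by methoxy in place of hydrogen on an aromatic carbon. Among the compounds with values here, with no single-point step available between measured compounds, the size of this change can only be guessed; since compound 1, which carries the same methoxy group, gives 3.6 nM, no step beyond the scatter is expected for a 1.0-fold lower number from compound 2 to compound 3 (0.01 log units; within the scatter). Compound 3 is therefore estimated at 3.2 nM, in the range 1.2 nM to 8.5 nM.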

Compound 3, half-maximal inhibitory concentration: 7.1 nM
The estimate for compound 3 lay 2.2-fold (0.35 log units) below the measured number; the range from low to high includes it.
By their numbers in this assay, from the lowest: compounds 2, 1 and 3 (each within the scatter of the next, the first and the last beyond it).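

In this assay, within the data shown here, methoxy in place of hydrogen on the aromatic carbon para to the (4-fluorophenyl)sulfonyl group gives a 2.2-fold higher number from compound 2 to compound 3 (0.33 log units; beyond the scatter), the first step at this position that can be read, and it shows that the position tolerates methoxy with only a modest loss. Fluoro in place of hydrogen on an aromatic carbon, with the methoxy present, gives a 2.0-fold higher number from compound 1 to compound 3 (0.29 log units; within the scatter), so that change cannot be told from no change on these data. Nothing measured on these compounds accounts for the methoxy step.

The compounds shown leave open whether this modest loss is particular to methoxy or would also come with a hydroxyl, a chlorine atom or an ethoxy group at the same position. They also leave open whether the methoxy step keeps its size on the sulfone without the fluoro.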